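Exchanging the Aryl Ether on the Core of Compound 1

A few compounds are considered here, and "the series" means these few. Any claim that something is new, unique, unknown or untested is made for them only; others in the source may bear on it.

Compound 1 `COc1cccc(Oc2ccc3c(NCCCNCc4cc(F)ccc4OC)ccnc3c2)c1` gives 9.28 in a physicochemical assay for acid dissociation. Compound 2 `COc1cccc(Oc2ccc3c(NCCCNCc4cccc(OC)c4O)ccnc3c2)c1` gives 9.28, and no change at the digits printed from compound 1 to compound 2 (within the scatter). Compound 3 `COc1cccc(CNCCCNc2ccnc3cc(CCC(C)C)ccc23)c1O` gives 9.47, and a number 0.19 log units higher from compound 2 to compound 3 (within the scatter). Compound 1 therefore stands level with compound 2 at the digits shown, the two together being the lowest of the three numbers, while compound 3 lies only a small way off and still within the scatter.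

Compound 4 `COc1ccc(F)cc1CNCCCNc1ccnc2cc(Cc3ccc(F)cc3)ccc12` has not yet been measured. It differs from compound 1 in one place: 4-fluorobenzyl in place of 3-methoxyphenoxy on an aromatic carbon. The measured step that bears on this change is the one at the same aromatic carbon of the shared core, where a number 0.19 log units higher from compound 2 to compound 3 (within the scatter). That exchange of the group on the core left the number essentially unchanged, and the chain carrying the amine nitrogen is untouched in compound 4. For this reason no step beyond the scatter is expected, and a number 0.07 log units higher from compound 1 to compound 4 (within the scatter) is the estimated outcome. Compound 4 is expected to give 9.35 in this assay, within a range from 9 to 9.7.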

Compound 4, acid dissociation constant: 9.47
The estimate for compound 4 lay 0.12 log units below the measured number; low and high end bracket the measured number.
By their numbers in this assay, from the lowest: compounds 1, 2, 3 and 4 (each within the scatter of the next).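

In this assay, the replacement of 3-methoxyphenoxy by 4-fluorobenzyl on this aromatic carbon gives a number 0.19 log units higher from compound 1 to compound 4 (within the scatter), so a second group at the position stays within the scatter, this time one that keeps an aromatic ring, and with 5-fluoro-2-methoxyphenyl on the chain rather than the 2-hydroxy-3-methoxyphenyl of the earlier exchange. The result also holds although 3-methoxyphenoxy counts 2 hydrogen-bond acceptors and 4-fluorobenzyl counts 0. Nothing available accounts for this absence of a step beyond the scatter.

Going by these compounds, all the groups compared at this position are uncharged, so it remains open whether an amine or a carboxylic acid there would shift the number beyond the scatter. The compounds shown also leave open whether a nitrile or a group on a longer chain would do so.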